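The compounds below may be only part of what the source reports. "The series", "measured", "known", "first", "only" and "open" are said of these compounds alone.

Working notes on the series, cytotoxicity in a functional assay on BT-549 cells (Homo sapiens) for cytotoxicity, read by sulforhodamine B assay, with a stated time of 72 h; a lower number here means a stronger inhibitor, a higher number a weaker inhibitor.

Going by the values given here, compound 3 `CCS(=O)(=O)Nc1cc(-c2ccc3ncnc(Nc4ccc(Cl)c(C(=O)OC)c4)c3c2)cnc1OC` gives 2360 nM and stands second highest of the three numbers so far. Nearest to it is compound 1 `CCS(=O)(=O)Nc1cc(-c2ccc3ncnc(Nc4ccc(F)cc4)c3c2)cnc1OC`, which gives 3120 nM; the step of a 1.3-fold lower number from compound 1 to compound 3 (0.12 log units; within the scatter) lies within the scatter. Furthest is compound 2 `CCS(=O)(=O)Nc1cc(-c2ccc3ncnc(Nc4cccc(C(=O)OC)c4)c3c2)cnc1OC`, which gives 1080 nM; the step of a 2.2-fold higher number from compound 2 to compound 3 (0.34 log units; beyond the scatter) lies beyond the scatter. Between the other two, the step of a 2.9-fold lower number from compound 1 to compound 2 (0.46 log units; beyond the scatter) is also beyond the scatter.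

Compound 4 `CCS(=O)(=O)Nc1cc(-c2ccc3ncnc(Nc4ccc(F)nc4)c3c2)cnc1OC` differs from compound 3 by 6-fluoropyridin-3-yl in place of 4-chloro-3-(methoxycarbonyl)phenyl on a nitrogen on an aromatic ring. Of the measured steps, the one that bears most directly on this change is a 1.3-fold lower number from compound 1 to compound 3 (0.12 log units; within the scatter), since compound 1 carries a 4-fluorophenyl on the same nitrogen and that exchange stayed within the scatter. The step of a 2.2-fold higher number from compound 2 to compound 3 (0.34 log units; beyond the scatter) shows that removing the chloro while keeping the methoxycarbonyl shifted the number modestly, but compound 4 keeps neither group. The fluoro-bearing ring of compound 4 is closer in make-up to compound 1 than to compound 2, so the number for compound 4 is expected near compound 1, with the step of a 1.3-fold higher number from compound 3 to compound 4 (0.10 log units; within the scatter) estimated not beyond the scatter. Compound 4 is therefore estimated at 3000 nM, with a range from 1200 nM to 7500 nM.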

Compound 4, half-maximal inhibitory concentration: 4780 nM
For compound 4 the middle estimate is 1.6-fold (0.20 log units) below the measured one; low and high end bracket the measured number.
By their numbers in this assay, from the lowest: compound 2; then compounds 3, 1 and 4 (each within the scatter of the next, the first and the last beyond it).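

In this assay, 6-fluoropyridin-3-yl on this nitrogen cannot be told apart from 4-fluorophenyl, as a 1.5-fold higher number from compound 1 to compound 4 (0.19 log units; within the scatter) shows, so a hetero atom in the ring of this fluoro-bearing group leaves no readable mark on the number. Set against the groups that carry methoxycarbonyl, the same ring gives a 2.0-fold higher number from compound 3 to compound 4 (0.31 log units; beyond the scatter) and a 4.4-fold higher number from compound 2 to compound 4 (0.65 log units; beyond the scatter), the second being the largest step at this position so far, and compound 2 now stands beyond the scatter from all three others, though compound 3 also carries methoxycarbonyl and stays within the scatter of compound 1, so that group alone does not set a compound apart. Nothing on hand gives a reason for these steps.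

Still open, as far as these compounds go, is whether a carboxylic acid or an amide in place of the methyl ester of the 3-(methoxycarbonyl)phenyl group would hold or improve on compound 2 at 1080 nM. Also open, from the compounds shown here alone, is how a basic amine such as a dimethylaminomethyl group on this ring would read, and whether the order of these groups would hold in other cell lines.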